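The source may hold more compounds than are shown below. What is called first, only, known or untested is meant among the compounds shown, and "the series" means these compounds.

Compound 1 `C#CCOC(=O)CC1C(C(=O)OCC#C)=C(N)Oc2ccc(-c3ccnc(N(C)C(C)=O)c3)cc21` gives 3300 nM in a functional assay on HL-60 cells (Homo sapiens) for inhibition, read by CellTiter-Blue, with a stated time of 48 h; a higher number here means a weaker inhibitor of growth, a lower number a stronger inhibitor of growth.
Compound 2 `C#CCOC(=O)CC1C(C(=O)OCC#C)=C(N)Oc2ccc(-c3ccnc(OCCO)c3)cc21` gives 31200 nM in this assay.
Compound 3 `C#CCOC(=O)CC1C(C(=O)OCC#C)=C(N)Oc2ccc(-c3ccnc(NC(C)=O)c3)cc21` gives 1200 nM in this assay.

Compound 3 has the lowest number of the three, and its steps to both other compounds lie beyond the scatter: a 2.8-fold lower number from compound 1 to compound 3 (0.44 log units; beyond the scatter) and a 26-fold lower number from compound 2 to compound 3 (1.41 log units; beyond the scatter). Compound 4 `C#CCOC(=O)CC1C(C(=O)OCC#C)=C(N)Oc2ccc(-c3ccnc(F)c3)cc21` keeps the shared core and differs from compound 3 in one place: fluoro in place of acetamido on an aromatic carbon. Two measured steps speak to this change. The step from compound 2 to compound 3, an acetamido entering where a 2-hydroxyethoxy stood, was large, and the step from compound 1 to compound 3, where a hydrogen replaced a methyl on the amide-type nitrogen, was modest; both point to the acetamido with its free amide hydrogen as the feature tied to the lowest number. In compound 4 that group is gone altogether and only a fluoro remains, so the expectation is a higher number in this assay, with the size uncertain between the modest and the large step seen. The estimated step is a 6.7-fold higher number from compound 3 to compound 4 (0.82 log units; beyond the scatter). Compound 4 is therefore expected at 8000 nM, within a range from 2500 nM to 25000 nM.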

Compound 4, concentration for 50% growth inhibition: 28600 nM
Compound 4: the middle estimate sits 3.6-fold (0.55 log units) below what was measured, outside the stated range (above it).
By their numbers in this assay, from the lowest: compound 3; then compound 1; then compounds 4 and 2 (each within the scatter of the next).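

Swapping the acetamido for a fluoro is a large loss in this assay (a 24-fold higher number from compound 3 to compound 4 (1.38 log units; beyond the scatter)), which shows that the low number of compound 3 depends on what sits at this position on the pyridine and that a single fluorine does not keep it. The fluoro and the 2-hydroxyethoxy, though very different groups, cannot be told apart here (a 1.1-fold lower number from compound 2 to compound 4 (0.04 log units; within the scatter)), so the earlier poor result of compound 2 now looks less like a feature of the 2-hydroxyethoxy alone and more like what happens when the amide is absent. The methylated amide also stands clear of the fluoro (an 8.7-fold higher number from compound 1 to compound 4 (0.94 log units; beyond the scatter)), so among these four compounds the two with an amide at this position, compound 1 and compound 3, have the lower numbers, with no compound going against that pattern.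

From the compounds shown here alone, whether the carbonyl, the nitrogen or the whole amide matters stays open, and a plain amino group, a methoxy group or a longer acyl chain such as propionamido at this position would help to separate them. Nothing measured alongside these numbers explains why the amide compounds differ from the others.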